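The source may report more compounds than this note shows. Statements on the series, on what has been measured and on what is new or still open speak of the compounds shown alone.

Measured so far:
Compound 1 `CC1CCC(Nc2nc(C(F)(F)F)ccc2CNC(=O)C(C)c2ccc(NS(C)(=O)=O)c(F)c2)CC1` gives 1130 nM in a functional assay on CHO-K1 cells for antagonist activity at transient receptor potential cation channel subfamily V member 1 (Homo sapiens), read by FLIPR; on this read-out higher numbers stand for weaker inhibition and lower numbers for stronger inhibition.
Compound 2 `CC(C(=O)NCc1ccc(C(F)(F)F)nc1N1CCCC1)c1ccc(NS(C)(=O)=O)c(F)c1` gives 211 nM in this assay.

Compound 2 stands lowest of the two numbers in this assay; its nearest neighbour is compound 1, and the step of a 5.4-fold lower number from compound 1 to compound 2 (0.73 log units; beyond the scatter) lies beyond the scatter. Compound 3 `CC(C(=O)NCc1ccc(C(F)(F)F)nc1N1CCC(C)(C)CC1)c1ccc(NS(C)(=O)=O)c(F)c1` is not yet measured. Relative to compound 2 it carries 4,4-dimethylpiperidin-1-yl in place of pyrrolidin-1-yl on an aromatic carbon. Within the data shown here, the single measured step touches the same position of the shared core, but it exchanges (4-methylcyclohexyl)amino for pyrrolidin-1-yl, not pyrrolidin-1-yl for 4,4-dimethylpiperidin-1-yl, so it bears on the present step only loosely and gives no direction to read from. The expectation for compound 3 in this assay is therefore a step of modest size or none beyond the scatter, as a 1.5-fold higher number from compound 2 to compound 3 (0.18 log units; within the scatter). Compound 3 is estimated at 320 nM in this assay, with a range from 100 nM to 1000 nM.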

Compound 3, half-maximal inhibitory concentration: 8 nM
Estimate against measurement, compound 3: 40-fold (1.60 log units) above; the whole stated range lies above it.
By their numbers in this assay, from the lowest: compound 3; then compound 2; then compound 1.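

Working notes on the series: in this assay, the position on an aromatic carbon next to the ring nitrogen proves highly sensitive, as 4,4-dimethylpiperidin-1-yl in place of pyrrolidin-1-yl gives a 26-fold lower number from compound 2 to compound 3 (1.42 log units; beyond the scatter). Exchanging (4-methylcyclohexyl)amino for 4,4-dimethylpiperidin-1-yl at the same place gives a 140-fold lower number from compound 1 to compound 3 (2.15 log units; beyond the scatter), so changes at this one position alone span a far wider range than the first step showed. No measurement at hand accounts for either step.

The compounds shown do not separate the move from a five-membered to a six-membered ring from the addition of the two methyl groups; unsubstituted piperidin-1-yl and 4-methylpiperidin-1-yl would bear on that. Also open, on these data alone, is how a morpholin-4-yl group, with its ring oxygen, would fare at this position.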